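The source may hold more compounds than are shown below. What is called first, only, known or untested is meant among the compounds shown, and "the series" means these compounds.

Three dialdehydes share the same pair of formyl-bearing rings and differ only in the spacer that joins the two aryl oxygens. Compound 1 `O=Cc1ccc(OCOc2ccc(C=O)cc2)cc1` has the shortest spacer, compound 2 `O=Cc1ccc(OCCCCCCCOc2ccc(C=O)cc2)cc1` a longer one, and compound 3 `O=Cc1ccc(OCCCCCCCCCCCOc2ccc(C=O)cc2)cc1` a longer one still. In an ADME assay on HepG2/C3A cells (Homo sapiens) for cytotoxicity, read by neutral red uptake, with a stated time of 24 h, tested at 180 uM (a higher number here means a weaker effect of the compound at the concentration tested, a lower number a stronger effect), compound 1 gives 78.6%, compound 2 gives 53.4%, and compound 3 gives 75.4%. Within this set compound 3 stands second highest: its nearest neighbour is compound 1, whose value lies within the scatter of it, while compound 2 lies furthest away, beyond the scatter, with the lower number.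

The next compound, compound 4 `O=Cc1ccc(OCCCCCCCCCCCCOc2ccc(C=O)cc2)cc1`, lengthens the spacer of compound 3 once more: (4-formylphenoxy)methyl in place of 4-formylphenoxy on a saturated chain carbon, ten or more bonds along the chain from an oxygen on an aromatic ring. Going by the values given here, no step between two measured compounds differing in a single place exists to guide the expectation. Compound 1 at 78.6% and compound 3 at 75.4% sit within the scatter of each other despite quite different spacers. The step of a number 1.4 percentage points lower from compound 3 to compound 4 (within the scatter) is therefore expected to be small, with no direction beyond the scatter. Compound 4 is estimated at 74% in this assay, within a range from 58% to 88%.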

Compound 4, a percentage reported as activity, at one concentration (the size of the read-out at that concentration, not a potency): 68.1%
For compound 4 the middle estimate is 5.9 percentage points above the measured one, within the range that was stated.
By their numbers in this assay, from the lowest: compound 2; then compounds 4, 3 and 1 (each within the scatter of the next, the first and the last beyond it).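

Going by these compounds alone, this is the first pair in the set that differs in one place, and so the first direct reading of a change at this position. In this assay, putting (4-formylphenoxy)methyl in place of 4-formylphenoxy on a saturated chain carbon, ten or more bonds along the chain from an oxygen on an aromatic ring, gives a number 7.3 percentage points lower from compound 3 to compound 4 (within the scatter), so at this position and at the one concentration tested, the change leaves the read-out indistinguishable from that of its parent, with compound 4 at 68.1% in this single comparison. No independent measurement is available to explain this result.

The compounds shown leave open whether the same holds at other places along the spacer, or for a longer chain at this position, since one pair cannot establish a trend with chain length. They also leave open whether the read-out would stay within the scatter if an amine or a carboxylic acid stood in place of a formyl group on either ring.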